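Hydrogen for nitro on compound 1: expected effect

A few compounds are considered here, and "the series" means these few. Any claim that something is new, unique, unknown or untested is made for them only; others in the source may bear on it.

Measured compounds:
compound 1 `O=[N+]([O-])c1ccc2[nH]c(CNc3c([N+](=O)[O-])ccc4ncccc34)nc2c1` — 274000 nM
compound 2 `O=[N+]([O-])c1ccc2[nH]c(CNc3nc4ccc(F)cc4s3)nc2c1` — 291000 nM

In a functional assay on MCF7 cells (Homo sapiens) for cytotoxicity, read by MTT assay (on this read-out lower numbers stand for stronger inhibition and higher numbers for weaker inhibition), compound 1 gives 274000 nM, and compound 2 gives 291000 nM. The two numbers lie within the usual scatter of one another, so compound 1 cannot be separated from compound 2; both sit far up the concentration scale. Among the measured compounds shown here, no step between measured compounds that differ in one place is available, so no measured step guides the next change.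

Compound 3 `O=[N+]([O-])c1ccc2ncccc2c1NCc1nc2ccccc2[nH]1` has not been measured. Against compound 1 the change is hydrogen in place of nitro on an aromatic carbon. Nothing in the measured pair speaks to this change: compound 2 differs from compound 1 in more than one place and carries a nitro group of its own. With compound 1 giving 274000 nM, the step is expected to be small, a 1.1-fold higher number from compound 1 to compound 3 (0.04 log units; within the scatter), not beyond the scatter in either direction. Compound 3 is therefore estimated at 300000 nM in this assay, with a range from 120000 nM to 800000 nM, and a limit rather than a number would not be surprising.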

Compound 3, half-maximal inhibitory concentration: 237000 nM
Beside the measured number, compound 3's estimate is 1.3-fold (0.10 log units) above it; low and high end bracket the measured number.
By their numbers in this assay, from the lowest: compounds 3, 1 and 2 (each within the scatter of the next).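

In this assay, hydrogen in place of nitro on this aromatic carbon gives a 1.2-fold lower number from compound 1 to compound 3 (0.06 log units; within the scatter), so compound 3 cannot be separated from compound 1 and this nitro group is not required to retain a number of this size. Among the compounds shown here, this is the only one-place step so far, and it shows that this position tolerates the loss of three heavy atoms without a change beyond the scatter. No independent data bear on the reason for this outcome.

As far as these compounds go, whether an amine, a carboxylic acid or a methoxy group on this same carbon would move the number beyond the scatter remains open. Also open, from the compounds shown here alone, is what hydrogen in place of the nitro group that remains on compound 3 would do.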